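Isobutyl to 2-(methylsulfanyl)ethyl on compound 3

A few compounds are considered here, and "the series" means these few. Any claim that something is new, unique, unknown or untested is made for them only; others in the source may bear on it.

In a functional assay on HeLa cells (Homo sapiens) for cytotoxicity, read by MTT assay, with a stated time of 72 h (a lower number here means a stronger inhibitor, a higher number a weaker inhibitor), three compounds have been measured so far. Compound 1 (`CC(C)(C)C1=CC(=O)C=C(NCC(=O)O)C1=O`) gives 132000 nM, compound 3 (`CC(C)C[C@H](NC1=CC(=O)C=C(C(C)(C)C)C1=O)C(=O)O`) gives 57200 nM, and compound 2 (`CC1=CCC[C@H]2[C@](C)(CC3=CC(=O)C=C(NCCC(=O)O)C3=O)[C@@H](C)CC[C@]12C`) gives 8870 nM. Compound 3 therefore holds the second highest of the three numbers, closer to compound 1 than to compound 2.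

Compound 4 (`CSCC[C@H](NC1=CC(=O)C=C(C(C)(C)C)C1=O)C(=O)O`) has not yet been measured. It carries (methylsulfanyl)methyl in place of isopropyl on a saturated chain carbon, two bonds along the chain from an amine nitrogen and a carbonyl carbon; cut one bond further out, this reads isobutyl to 2-(methylsulfanyl)ethyl: (methylsulfanyl)methyl in place of isopropyl on a saturated chain carbon, two bonds along the chain from an amine nitrogen and a carbonyl carbon.

Within the data shown here, only one measured step bears on this change. Putting isobutyl in place of hydrogen gave a 2.3-fold lower number from compound 1 to compound 3 (0.36 log units; beyond the scatter), a modest step beyond the scatter. Among the measured compounds shown here, no measured step exchanges one such chain for another. For the measured compounds named here, with compound 3 having gained only that modest step from its whole isobutyl group, a swap of that group is expected to move the number less. The estimated change is a 1.1-fold higher number from compound 3 to compound 4 (0.06 log units; within the scatter), a slightly higher number that is expected to stay within the scatter. Compound 4 is expected at about 65000 nM, with an estimated range from 30000 nM to 130000 nM.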

Compound 4, half-maximal inhibitory concentration: 77400 nM
The estimate for compound 4 lay 1.2-fold (0.08 log units) below the measured number, within the range that was stated.
By their numbers in this assay, from the lowest: compound 2; then compounds 3, 4 and 1 (each within the scatter of the next, the first and the last beyond it).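

In this assay this position accepts a sulfur atom in its side chain with no shift that can be resolved, as the exchange of isopropyl for (methylsulfanyl)methyl gives a 1.4-fold higher number from compound 3 to compound 4 (0.13 log units; within the scatter) and so leaves the two chains indistinguishable. Set against hydrogen, however, the two chains read differently: 2-(methylsulfanyl)ethyl gives a 1.7-fold lower number from compound 1 to compound 4 (0.23 log units; within the scatter) and stays inside the scatter, whereas isobutyl gives a 2.3-fold lower number from compound 1 to compound 3 (0.36 log units; beyond the scatter) and just clears it, so the modest gain seen with isobutyl is not clearly shared by a chain of the same heavy-atom count. Nothing available explains either step or the small difference between these readings.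

The compounds shown leave open whether any side chain at this carbon can move the number well beyond these modest steps, since a longer alkyl chain, a phenyl ring, a primary amine or a hydroxyl group does not appear among them. They also leave open whether a sulfoxide in place of the sulfide, or an amide or ester in place of the carboxylic acid, would change the reading on this core.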